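Heteroaryl swap on the aniline core: compound 4 expected

The compounds below may be only part of what the source reports. "The series", "measured", "known", "first", "only" and "open" are said of these compounds alone.

Compound 1, `c1coc(-c2ccccc2NCC2=NCCN2)c1`: in a functional assay for activation of Alpha-1B adrenergic receptor (Homo sapiens), read by calcium flux (a lower number here means that less compound is needed, a higher number that more compound is needed for the effect), compound 1 gives 6.31 nM.
Compound 2, `c1csc(-c2ccccc2NCC2=NCCN2)c1`: in this assay compound 2 gives 5.75 nM.
Compound 3, `c1ccc(-c2cnoc2)c(NCC2=NCCN2)c1`: in this assay compound 3 is reported only as a limit, < 100000 nM.

Compound 3 thus stands at the limit (the limit of < 100000 nM in this assay, at which 1 of the 3 values shown sits), with no number of its own. For the measured compounds named here, the only readable step among the three is a 1.1-fold lower number from compound 1 to compound 2 (0.04 log units; within the scatter). The steps a step that the limit leaves unreadable from compound 1 to compound 3 and a step that the limit leaves unreadable from compound 2 to compound 3 cannot be sized, because compound 3 is known only by its limit < 100000 nM.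

Compound 4, `c1ccc(-c2ccccc2NCC2=NCCN2)nc1`, differs from compound 3 by pyridin-2-yl in place of 1,2-oxazol-4-yl on an aromatic carbon. Going by the values given here, no measured step bears directly on this change, since both steps ending at compound 3 are unreadable; the change in compound 4 is therefore judged against compound 1 and compound 2, whose values in this assay lie within the scatter of each other. Compound 4 is expected to fall nearer those two, with the step that the limit leaves unreadable from compound 3 to compound 4 an estimate rather than a measured quantity. Compound 4 is estimated at 80 nM in this assay, within the range 5 nM to 3000 nM.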

Compound 4, half-maximal effective concentration: 30.2 nM
The estimate for compound 4 lay 2.6-fold (0.42 log units) above the measured number, and the stated range covers the measured number.
By their numbers in this assay, from the lowest: compounds 2 and 1 (each within the scatter of the next); then compound 4.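

In this assay, compound 4 shows that this place, on an aromatic carbon ortho to a group of 7 heavy atoms, takes a six-membered aromatic ring and still gives a low number, which the five-membered rings alone could not show. Pyridin-2-yl does carry a modest cost against both five-membered rings that gave readable numbers (a 5.3-fold higher number from compound 2 to compound 4 (0.72 log units; beyond the scatter)) and (a 4.8-fold higher number from compound 1 to compound 4 (0.68 log units; beyond the scatter)). The steps that involve compound 3 cannot be read, because compound 3 is known only as a limit: the limit of < 100000 nM in this assay, at which 1 of the 4 values shown sits.

What the compounds shown leave open is how a plain phenyl ring or a pyridin-3-yl group would compare at this place. Also open, as far as these compounds go, is whether an amine or a carboxylic acid on the pyridine ring would move the number.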